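From Anilide to Thiazolylamide in a Cell Toxicity Assay

The source may report more compounds than this note shows. Statements on the series, on what has been measured and on what is new or still open speak of the compounds shown alone.

Compound 1, `COc1cc2nc(C)cc(OCC(=O)Nc3cc(C)cc(C)c3)c2cc1OC`: 10000 nM in a toxicity assay on HepG2 cells (Homo sapiens) for inhibition, read by CellTiter-Glo, with a stated time of 48 h; a lower number here means a stronger inhibitor, a higher number a weaker inhibitor
Compound 2, `COc1ccc2nc(C)cc(NC(=O)C(=O)Nc3cc(C)cc(C)c3)c2c1`: > 100000 nM in this assay
Compound 3, `COc1ccc2nc(C)cc(OCC(=O)Nc3ccccc3)c2c1`: 39800 nM in this assay

In this assay compound 3 gives 39800 nM, the highest of the two numbers shown; compound 1 gives the lower number, 10000 nM. For compound 2 the result is only a limit, > 100000 nM, and not a number (the limit of > 100000 nM in this assay, at which 1 of the 3 values shown sits).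

Compound 4, `COc1ccc2nc(C)cc(OCC(=O)Nc3nc(C)c(C)s3)c2c1`, has not yet been tested. It differs from compound 3 in one place: 4,5-dimethyl-1,3-thiazol-2-yl in place of phenyl on an amide-type nitrogen. Among the compounds with values here, no measured pair shows this change, so the step is expected to stay small, likely within the scatter, or to lower the number a little: from compound 3 to compound 4 an estimated 1.3-fold lower number from compound 3 to compound 4 (0.12 log units; within the scatter). Compound 4 is thus expected near 30000 nM, within 8000 nM to 100000 nM.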

Compound 4, half-maximal inhibitory concentration: > 100000 nM
Compound 4 ended at the assay's limit; the forecaster's own chance of this, stated with the estimate: 25%; middle value at least 3.3-fold (0.52 log units) away from the limit.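

Among the compounds shown, this is the only step that changes one place, and it shows that the group on the amide-type nitrogen matters in this assay: 4,5-dimethyl-1,3-thiazol-2-yl in place of phenyl gives an at least 2.5-fold higher number from compound 3 to compound 4 (0.40 log units; beyond the scatter), towards a weaker inhibitor. Compound 4 gives > 100000 nM, which is a limit of the assay and not a number, so the full size of the step cannot be read. The limit now recurs in the series: the limit of > 100000 nM in this assay, at which 2 of the 4 values shown sit.

On these data alone, whether the two methyl groups or the ring itself carry this step stays open, as an unsubstituted 1,3-thiazol-2-yl would test. As far as these compounds go, how a pyridin-2-yl or a benzyl on the same nitrogen would read also remains unknown.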